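The compounds below may be only part of what the source reports. "The series", "measured", "known", "first", "only" and "open" are said of these compounds alone.

In a functional assay on MDA-MB-231 cells (Homo sapiens) for inhibition, read by MTT assay, with a stated time of 24 h (on this read-out lower numbers stand for stronger inhibition and higher numbers for weaker inhibition), three compounds have been measured. Compound 1 `[O-]/[N+](=C\c1cn(-c2ccc(F)cc2)nn1)Cc1ccccc1` gives only a limit, > 100000 nM. Compound 2 `[O-]/[N+](=C\c1cn(CCC(F)(F)C(F)(F)C(F)(F)C(F)(F)C(F)(F)C(F)(F)F)nn1)Cc1ccccc1` likewise gives only a limit, > 100000 nM. Among the compounds with values here, compound 3 `[O-]/[N+](=C\c1cn(CCC(F)(F)C(F)(F)C(F)(F)C(F)(F)C(F)(F)C(F)(F)C(F)(F)C(F)(F)F)nn1)Cc1ccccc1` gives 8400 nM, the only actual number among the three; the other two sit at the limit of > 100000 nM in this assay, at which 2 of the 3 values shown sit. Within the data shown here, the single step between measured compounds, an at least 11-fold lower number from compound 2 to compound 3 (1.07 log units; beyond the scatter), is large and lies beyond the scatter.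

Compound 4 `CC(C)(C)/[N+]([O-])=C/c1cn(CCC(F)(F)C(F)(F)C(F)(F)C(F)(F)C(F)(F)C(F)(F)C(F)(F)C(F)(F)F)nn1` differs from compound 3 by tert-butyl in place of benzyl on a double-bonded nitrogen. Among the measured compounds shown here, no measured step bears directly on this change: the one step measured altered a different part of the molecule and left the benzyl untouched, so it offers no guide to what removing the benzyl does. With no evidence either way, the step of a 1.8-fold higher number from compound 3 to compound 4 (0.25 log units; within the scatter) is expected to be small, within the scatter, though with wide uncertainty. Compound 4 is accordingly estimated at 15000 nM in this assay, with a range from 4000 nM to 60000 nM.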

Compound 4, half-maximal inhibitory concentration: 29700 nM
Beside the measured number, compound 4's estimate is 2.0-fold (0.30 log units) below it; the range from low to high includes it.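

With the fluorinated chain held the same, the nitrogen substituent proves to be a second place where the read-out responds, as tert-butyl in place of benzyl gives a 3.5-fold higher number from compound 3 to compound 4 (0.55 log units; beyond the scatter) in this assay, a modest step towards weaker inhibition. The benzyl, with its six-membered aromatic ring, is therefore not required for a measurable number, though compound 3 with that group inhibits more strongly than compound 4. Compound 4 still gives an actual number, so it stays clear of the ceiling of the assay: the limit of > 100000 nM in this assay, at which 2 of the 4 values shown sit.

From the compounds shown here alone, what remains open is whether the aromatic ring or simply the carbon framework of the benzyl accounts for the step, which a cyclohexylmethyl or a phenethyl group on the same nitrogen would help to separate. Also open, going by these compounds, is how tert-butyl behaves on the shorter chain of compound 2.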